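The source may hold more compounds than are shown below. What is called first, only, known or untested is meant among the compounds shown, and "the series" means these compounds.

Compound 1 `CC1CC(=O)c2s/c(=N/c3ccccc3)oc2C1` and compound 2 `CC(C)C1CC(=O)c2s/c(=N/c3ccccc3)oc2C1` share one core and were both tested in a functional assay on NUGC-3 cells (Homo sapiens) for antiproliferative activity, read by sulforhodamine B assay; on this read-out lower numbers stand for stronger inhibition of growth and higher numbers for weaker inhibition of growth. Compound 1 gives 1890 nM. Compound 2 gives 1220 nM, and the change a 1.5-fold lower number from compound 1 to compound 2 (0.19 log units; within the scatter) leaves the two within the scatter of each other, so neither stands apart. Compound 3 `CC(C)C1CC(=O)c2s/c(=N/C3CCCCC3)oc2C1` has not yet been measured. It differs from compound 2 by cyclohexyl in place of phenyl on a double-bonded nitrogen. Going by the values given here, the one measured step, a 1.5-fold lower number from compound 1 to compound 2 (0.19 log units; within the scatter), concerns a substituent on a saturated ring carbon, not the group on the double-bonded nitrogen, so no measured step bears directly on this change. On that basis no step beyond the scatter in this assay is expected in either direction, and the expected step is a 1.2-fold higher number from compound 2 to compound 3 (0.09 log units; within the scatter), held with wide uncertainty. Compound 3 is therefore estimated at 1500 nM, within a range from 400 nM to 6000 nM.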

Compound 3, concentration for 50% growth inhibition: 2710 nM
Compound 3: middle estimate off by 1.8-fold (0.26 log units), on the low side, within the range that was stated.
By their numbers in this assay, from the lowest: compounds 2, 1 and 3 (each within the scatter of the next, the first and the last beyond it).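

In this assay, going by these compounds alone, the group on the double-bonded nitrogen is the first place in this set where a single change carries the number beyond the scatter (a 2.2-fold higher number from compound 2 to compound 3 (0.35 log units; beyond the scatter)), with cyclohexyl in place of phenyl. Phenyl and cyclohexyl match in their counts of heavy atoms, hydrogen-bond donors and hydrogen-bond acceptors, so this pair sets an aromatic against a non-aromatic six-membered ring of carbon, and the aromatic ring goes with the lower number, though the step is modest and rests on this one pair. Nothing at hand accounts for the difference between the two rings.

The compounds shown leave open whether the same step appears when methyl rather than isopropyl sits on the saturated ring carbon. They also leave open how a phenyl ring carrying an amine or a carboxylic acid, or an open chain such as n-hexyl, would compare on the double-bonded nitrogen.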